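This account rests on a few compounds, and the source may have more. Where it says the series, first, only, none or still open, it means among the compounds named here.

Compound 2 `O=C(O)Cc1sc(C(c2ccc(F)cc2)c2ccc(F)cc2)nc1-c1ccccc1` gives 16 nM in an in vitro assay on HEK385-7 cells for displacement of a labelled ligand from prostaglandin D2 receptor 2 (Homo sapiens) (on this read-out lower numbers stand for stronger inhibition and higher numbers for weaker inhibition), the highest of the two numbers measured; its nearest neighbour, compound 1 `O=C(O)Cc1sc(C(c2ccc(F)cc2)c2ccc(F)cc2)nc1-c1ccc(Cl)cc1`, gives 9.7 nM, and the step of a 1.6-fold higher number from compound 1 to compound 2 (0.22 log units; within the scatter) is within the scatter. Compound 3 `O=C(O)Cc1sc(C(c2ccc(F)cc2)c2ccc(F)cc2)nc1-c1cccc(F)c1` differs from compound 2 in one place: fluoro in place of hydrogen on an aromatic carbon, on an aromatic carbon of a six-membered aromatic ring of carbon only, meta to a large group; cut one bond further out, the change reads phenyl to 3-fluorophenyl. Among the compounds with values here, the only measured step that bears on it is the change on the same ring, a 1.6-fold higher number from compound 1 to compound 2 (0.22 log units; within the scatter), which stayed within the scatter when chloro gave way to hydrogen. A single fluoro entering that ring is therefore expected to move this assay by no more than the scatter, in either direction, with compound 3 estimated at 13 nM, between 5 nM and 32 nM, a step of a 1.2-fold lower number from compound 2 to compound 3 (0.09 log units; within the scatter).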

Compound 3, half-maximal inhibitory concentration: 1.4 nM
The estimate for compound 3 lay 9.3-fold (0.97 log units) above the measured number; the whole stated range lies above it.
By their numbers in this assay, from the lowest: compound 3; then compounds 1 and 2 (each within the scatter of the next).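

In this assay, the ring that had seemed insensitive to substitution proves responsive: fluoro in place of hydrogen, on an aromatic carbon meta to a large group, gives an 11-fold lower number from compound 2 to compound 3 (1.06 log units; beyond the scatter), whereas removing chloro had given only a 1.6-fold higher number from compound 1 to compound 2 (0.22 log units; within the scatter). The change from 4-chlorophenyl to 3-fluorophenyl gives a 6.9-fold lower number from compound 1 to compound 3 (0.84 log units; beyond the scatter), so the two halogen-bearing compounds do not behave alike, and compound 3 has the lowest number of the three, with its steps to both others beyond the scatter. Nothing available explains this gain.

The compounds shown do not separate the effect of the group from that of its place, a question that 3-chlorophenyl and 4-fluorophenyl would address directly. From the compounds shown here alone, it also remains open whether the gain is specific to halogens or extends to a methyl or methoxy group on the same carbon.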